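The source may hold more compounds than are shown below. What is called first, only, known or untested is meant among the compounds shown, and "the series" means these compounds.

Measured in a functional assay on Ishikawa cells (Homo sapiens) for antiproliferative activity, read by CCK-8 assay, with a stated time of 48 h; a higher number here means a weaker inhibitor, a lower number a stronger inhibitor:
- compound 1 `C=C(C)C(=O)NCCOc1ccc(Oc2c(-c3ccc(F)cc3)sc3cc(O)ccc23)cc1`: > 25000 nM
- compound 2 `O=C(/C=C/CN1CC(Oc2ccc(Oc3c(-c4ccc(F)cc4)sc4cc(O)ccc34)cc2)C1)N1CCC1`: 5450 nM

The entry for compound 1 is a limit and not a number. Among the compounds with values here, compound 2, at 5450 nM, therefore holds the only actual number so far, and the account has a single numerical point from which to work.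

The next compound to be tested is compound 3 `C=CC(=O)N1CC(Oc2ccc(Oc3c(-c4ccc(F)cc4)sc4cc(O)ccc34)cc2)C1`, which shares the core of compound 2. It carries vinylcarbonyl in place of 3-((azetidin-1-yl)carbonyl)prop-2-en-1-yl on an amine nitrogen in a ring. All other parts of the structure stay the same.

Within the data shown here, no measured step between closely matched compounds is available as a guide to this change. The expectation in this assay is therefore for no shift beyond the usual scatter, in either direction, and the uncertainty remains wide. The estimated step is a 1.1-fold higher number from compound 2 to compound 3 (0.04 log units; within the scatter). For compound 3 the estimated value is 6000 nM, with an expected range from 1800 nM to 20000 nM.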

Compound 3, half-maximal inhibitory concentration: 12300 nM
The estimate for compound 3 lay 2.1-fold (0.31 log units) below the measured number; measured number inside the range.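

In this assay, within the data shown here, the change on the amine nitrogen of the four-membered ring gives the first step that can be read at this position: vinylcarbonyl in place of 3-((azetidin-1-yl)carbonyl)prop-2-en-1-yl brings a 2.3-fold higher number from compound 2 to compound 3 (0.35 log units; beyond the scatter), so the larger group goes with the lower number here, though only modestly. The change on the oxygen on an aromatic ring, 1-(vinylcarbonyl)azetidin-3-yl in place of 2-(((1-methylethenyl)carbonyl)amino)ethyl, brings an at least 2.0-fold lower number from compound 1 to compound 3 (0.30 log units; that floor lies within the scatter), and this floor does not by itself set the two compounds apart beyond the scatter. Compound 1 is recorded only as a limit of the assay, not as a number, and so its true distance from the others stays unknown: the limit of > 25000 nM in this assay, at which 1 of the 3 values shown sits.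

The compounds shown leave open whether the lower number of compound 2 goes with the azetidin-1-yl group itself or with the longer chain that carries it, and a dimethylamine or a piperidine in place of the azetidin-1-yl group would separate the two. Also open, on these data alone, is what a saturated propanoyl group on the same ring nitrogen would give in place of vinylcarbonyl.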